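The source may hold more compounds than are shown below. What is called first, only, known or untested is meant among the compounds shown, and "the series" means these compounds.

Compound 2 `C=C(Br)C(=O)Nc1cccc(-c2cn3nc(-c4ccc(Cl)cc4)sc3n2)c1` gives 3200 nM in a functional assay on CCRF-CEM cells (Homo sapiens) for inhibition, read by cell counting, with a stated time of 3 days (on this read-out higher numbers stand for weaker inhibition and lower numbers for stronger inhibition), the highest of the two numbers at hand, although compound 1 `C=C(Br)C(=O)Nc1cccc(-c2cn3nc(Cc4cccc(OC)c4)sc3n2)c1`, which gives 3100 nM, sits within the scatter of it. Compound 3 `C=C(Br)C(=O)Nc1cccc(-c2cn3nc(-c4cccc(OC)c4)sc3n2)c1` differs from compound 2 by 3-methoxyphenyl in place of 4-chlorophenyl on an aromatic carbon. Within the data shown here, the one measured step bearing on this position, a 1.0-fold higher number from compound 1 to compound 2 (0.01 log units; within the scatter), lay within the scatter, so the shared core tolerated two quite different groups there without a clear shift. For compound 3 a step of a 1.1-fold lower number from compound 2 to compound 3 (0.03 log units; within the scatter) is therefore expected, none beyond the scatter. Compound 3 is estimated at 3000 nM, with a range from 1200 nM to 8000 nM.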

Compound 3, half-maximal inhibitory concentration: 1200 nM
Beside the measured number, compound 3's estimate is 2.5-fold (0.40 log units) above it; the range from low to high includes it.
By their numbers in this assay, from the lowest: compound 3; then compounds 1 and 2 (each within the scatter of the next).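

This position is less indifferent than the first two compounds suggested: 3-methoxyphenyl in place of 4-chlorophenyl gives a 2.7-fold lower number from compound 2 to compound 3 (0.43 log units; beyond the scatter), a modest but real shift. The same ring also reads differently with and without the carbon link of 3-methoxybenzyl, with a 2.6-fold lower number from compound 1 to compound 3 (0.41 log units; beyond the scatter) when that link is absent. Nothing measured here explains either step.

As far as these compounds go, whether the lower number follows the methoxy group itself or its place on the ring stays open. A 4-methoxyphenyl, a plain phenyl or a ring carrying an amine could help to settle this.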